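The source may report more compounds than this note shows. Statements on the series, on what has been measured and on what is new or still open speak of the compounds shown alone.

Compound 1 `CN1CCN(c2ccc3[nH]nc(S(=O)(=O)c4ccccc4Cl)c3c2)CC1` gives 100% in a functional assay on HeLa cells for antagonist activity at 5-hydroxytryptamine receptor 6 (Homo sapiens); on this read-out lower numbers stand for smaller maximal responses and higher numbers for larger maximal responses
Compound 2 `CN1CCN(c2cccc3c(S(=O)(=O)c4cccc5ccccc45)n[nH]c23)CC1` gives 100%
Compound 3 `Cn1nc(S(=O)(=O)c2ccccc2)c2cc(N3CCNCC3)ccc21` gives 100%

In this assay compound 1 stands level with compounds 2 and 3 at the digits shown; its nearest neighbour is compound 2 and its furthest is compound 3, and both gaps lie within the usual scatter of the method. Among the compounds with values here, no step between two measured compounds that differ in a single place is available, so the size of any change can only be anticipated. Compound 4 `Cc1ccc(S(=O)(=O)c2n[nH]c3ccc(N4CCN(C)CC4)cc23)cc1` is the next compound to be measured in this assay. It differs from compound 1 in one place: 4-methylphenyl in place of 2-chlorophenyl on a sulfonyl sulfur. Given that compounds 1, 2 and 3 all sit at the same level, the step of no change at the digits printed from compound 1 to compound 4 (within the scatter) is expected to stay within the scatter, with no change beyond it in either direction. Compound 4 is therefore estimated at 100%, in the range 88% to 100%.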

Compound 4, largest response reached (reported as Imax), in percent of the reference or control that the assay uses: 100%
Estimate against measurement, compound 4: no gap at the digits printed; low and high end bracket the measured number.
By their numbers in this assay, from the lowest: compounds 1, 2, 3 and 4 (each within the scatter of the next).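

In this assay, 4-methylphenyl in place of 2-chlorophenyl on a sulfonyl sulfur gives no change at the digits printed from compound 1 to compound 4 (within the scatter) in the first single-place comparison available here. At this position, the read-out therefore does not separate these two aryl groups, which have the same heavy-atom count but differ in chlorine and methyl. No measured evidence bears on this result. Still open, on these data alone, is whether that level would hold with cyclohexyl on the sulfonyl sulfur, or with a phenyl ring carrying a carboxylic acid or an amine.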